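Swapping a furan for a fluoromethoxyphenyl on a basic amine

A few compounds are considered here, and "the series" means these few. Any claim that something is new, unique, unknown or untested is made for them only; others in the source may bear on it.

Of the compounds shown here, three sharing one core have been measured in a physicochemical assay for acid dissociation. Compound 1 `COc1ccc(F)cc1CNCCCNc1ccnc2cc(C3CCCCC3)ccc12` gives 9.47. Compound 2 `Fc1ccc(Cc2ccc3c(NCCCNCc4ccco4)ccnc3c2)c(Cl)c1` gives 9.47, level with compound 1 at the digits shown. Compound 3 `Cc1cc(C)cc(Cc2ccc3c(NCCCNCc4ccco4)ccnc3c2)c1` gives 9.47, so all three sit together within the scatter, and the step of no change at the digits printed from compound 2 to compound 3 (within the scatter) shows that exchanging the group on the saturated chain carbon bound to an aromatic carbon leaves the read-out untouched.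

Compound 4 `COc1ccc(F)cc1CNCCCNc1ccnc2cc(Cc3ccc(F)cc3Cl)ccc12` has not yet been measured. It differs from compound 2 at the other end of the chain: 5-fluoro-2-methoxyphenyl in place of furan-2-yl on a saturated chain carbon bound to an amine nitrogen. For the measured compounds named here, compound 1 already carries the entering 5-fluoro-2-methoxybenzyl group in the same place and still gives 9.47, and the single measured step from compound 2 to compound 3 was flat. On that basis the expected step of no change at the digits printed from compound 2 to compound 4 (within the scatter) is none beyond the scatter. Compound 4 is therefore estimated to give 9.47, with a range from 9.17 to 9.77.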

Compound 4, acid dissociation constant: 9.47
For compound 4 middle estimate and measured number coincide at the digits printed, and the stated range covers the measured number.
By their numbers in this assay, from the lowest: compounds 1, 2, 3 and 4 (each within the scatter of the next).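

In this assay, replacing furan-2-yl with 5-fluoro-2-methoxyphenyl on a saturated chain carbon bound to an amine nitrogen gives no change at the digits printed from compound 2 to compound 4 (within the scatter) and is the only step shown at this place, where a five-membered ring with 5 heavy atoms gives way to a six-membered ring with 9. At the other end of the molecule, the step of no change at the digits printed from compound 1 to compound 4 (within the scatter) comes from 2-chloro-4-fluorobenzyl in place of cyclohexyl on an aromatic carbon, so that position now has a flat step of its own. No supporting evidence is available to explain these flat results.

Every compound shown stays level, so no change that moves the number has yet appeared. Still open, going by these compounds, is whether a carboxylic acid or a pyridine ring at the amine-side position, or a longer chain, would shift it.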